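The compounds below may be only part of what the source reports. "The series", "measured", "known", "first", "only" and "open" are said of these compounds alone.

Measured compounds:
Compound 1, `CSc1nc(NCCCCCO)c2ccccc2n1` — 31400 nM
Compound 2, `CSc1nc(Nc2ccccc2)c2ccccc2n1` — 55800 nM
Compound 3, `CCCCCSc1nc(NCc2ccc([Se]C)cc2)c2ccccc2n1` — 19800 nM

In a functional assay on HTB-54 cells (Homo sapiens) for cytotoxicity, read by MTT assay, with a stated time of 72 h (on this read-out higher numbers stand for weaker inhibition of growth and lower numbers for stronger inhibition of growth), compound 1 gives 31400 nM, the second highest of the three numbers. Its nearest neighbour is compound 3, at 19800 nM, and the furthest is compound 2, at 55800 nM; both gaps are within the scatter, so the three measured compounds cannot be told apart on these numbers.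

The unmeasured compound 4, `CSc1nc(NCCCCc2ccccc2)c2ccccc2n1`, differs from compound 1 in one place: phenyl in place of hydroxymethyl on a saturated chain carbon, four bonds along the chain from a nitrogen on an aromatic ring. Within the data shown here, the only measured step that bears on it is the one from compound 1 to compound 2, a 1.8-fold higher number from compound 1 to compound 2 (0.25 log units; within the scatter), where the chain is replaced rather than extended, and it stayed within the scatter. Among the measured compounds shown here, compound 3, carrying a benzyl on the nitrogen, sits at the lowest of the three numbers, but no single step links it to compound 1. On this basis compound 4 is expected to show a 1.4-fold lower number from compound 1 to compound 4 (0.15 log units; within the scatter), no more than a shift within the usual scatter. The estimate for compound 4 is 22000 nM, with a range from 8000 nM to 60000 nM.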

Compound 4, concentration for 50% growth inhibition: > 100000 nM
Compound 4: only a limit was reported (the forecaster's own chance of this, stated with the estimate: 5%); middle value at least 4.5-fold (0.65 log units) from the limit.
By their numbers in this assay, from the lowest: compounds 3, 1 and 2 (each within the scatter of the next, the first and the last beyond it). At a limit, above all of these: compound 4.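

In this assay, putting phenyl in place of hydroxymethyl on a saturated chain carbon, four bonds along the chain from a nitrogen on an aromatic ring, gives an at least 3.1-fold higher number from compound 1 to compound 4 (0.50 log units; beyond the scatter), the first step among these compounds to lie beyond the scatter. Compound 4 stands at a limit of the assay, not at a number: the limit of > 100000 nM in this assay, at which 1 of the 4 values shown sits. Among these compounds, this position therefore responds to the change, whereas the only earlier step, a 1.8-fold higher number from compound 1 to compound 2 (0.25 log units; within the scatter), did not leave the scatter.

The compounds shown do not separate the loss of hydroxymethyl from the arrival of phenyl, and the true size of the step stays unknown. From the compounds shown here alone, whether an amine or a carboxylic acid in the same place would keep the number close to that of compound 1 also remains open.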